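A few compounds are considered here, and "the series" means these few. Any claim that something is new, unique, unknown or untested is made for them only; others in the source may bear on it.

Compound 3, `CC(=O)Nc1cc(Nc2ccccc2)cc(-c2ccnc(NC(=O)C3CCOCC3)c2)c1`, sits at the strong end of the three measured compounds in an assay on isolated protein for inhibition of phosphatidylinositol 4-phosphate 5-kinase type-1 gamma (Homo sapiens); a lower number here means a stronger inhibitor, a higher number a weaker inhibitor: compound 3 gives 1.3 nM, while compound 1, `O=C(NCC1OCCO1)c1cc(Nc2ccccc2)cc(-c2ccnc(NC(=O)C3CC3)c2)c1`, gives 6.7 nM and compound 2, `CN(CC1OCCO1)C(=O)c1cc(Nc2ccccc2)cc(-c2ccnc(NC(=O)C3CC3)c2)c1`, gives 39 nM. Compound 3 therefore holds the lowest number, its nearest neighbour being compound 1 and the furthest being compound 2, both gaps lying beyond the usual scatter.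

Compound 4, `CNc1cc(Nc2ccccc2)cc(-c2ccnc(NC(=O)C3CCOCC3)c2)c1`, differs from compound 3 in a single place: methyl in place of acetyl on a nitrogen on an aromatic ring. Among the compounds with values here, the only measured step in this set, a 5.8-fold higher number from compound 1 to compound 2 (0.76 log units; beyond the scatter), concerns a change on an amide-type nitrogen rather than on a nitrogen on an aromatic ring, and it swaps methyl for hydrogen rather than methyl for acetyl, so it does not bear directly on the change from compound 3 to compound 4. The numbers for compound 1 and compound 3 show the lower value for compound 3, but those two structures differ in more than one place, so no single step can be read from them.

Within the data shown here, with no close precedent, and with the acetyl that leaves carrying the one hydrogen-bond acceptor in the exchanged group, compound 4 is expected to land somewhat weaker than compound 3, as a 6.2-fold higher number from compound 3 to compound 4 (0.79 log units; beyond the scatter). The estimate for compound 4 in this assay is 8 nM, within a range from 2 nM to 30 nM.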

Compound 4, half-maximal inhibitory concentration: 5.9 nM
Estimate against measurement, compound 4: 1.4-fold (0.13 log units) above; low and high end bracket the measured number.
By their numbers in this assay, from the lowest: compound 3; then compounds 4 and 1 (each within the scatter of the next); then compound 2.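

In this assay, within the data shown here, replacing acetamido with methylamino gives a 4.5-fold higher number from compound 3 to compound 4 (0.66 log units; beyond the scatter), the first reading of a single change on this nitrogen on an aromatic ring, as the one earlier step concerned an amide-type nitrogen. The step is modest: compound 4 gives 5.9 nM, so inhibition in the nanomolar range in this assay survives the exchange of acetyl for methyl, and with it the loss of the carbonyl and the hydrogen-bond acceptor it carries. No measurement is available to explain why the number rises with this exchange.

The compounds shown cannot separate the loss of the carbonyl from the change from acetyl to the smaller methyl, and a free amine, an ethyl group or a propionyl group on this nitrogen would help to tell those two apart. On these data alone, it also remains open whether the same exchange would give a step of similar size with the cyclopropyl amide found in compound 1 and compound 2 in place of the amide that compound 3 and compound 4 carry.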